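The source may hold more compounds than are shown below. What is called first, only, known or untested is meant among the compounds shown, and "the series" means these compounds.

Measured in a functional assay on MCF7 cells (Homo sapiens) for inhibition, read by MTT assay, with a stated time of 3 days; a higher number here means a weaker inhibitor, a lower number a stronger inhibitor:
- Compound 1 `Cc1cc(=O)oc2cc(OCC(=O)N/N=C/c3ccc(N(C)C)cc3)ccc12`: 5540 nM
- Compound 2 `Cc1cc(=O)oc2cc(OCC(=O)N/N=C/c3ccc(F)cc3)ccc12`: 9780 nM
- Compound 3 `Cc1ccc(/C=N/NC(=O)COc2ccc3c(C)cc(=O)oc3c2)o1`: 3190 nM

Compound 3 shares the low end of this small set with compound 1. The step of a 3.1-fold lower number from compound 2 to compound 3 (0.49 log units; beyond the scatter) separates it from compound 2, whereas the step of a 1.7-fold lower number from compound 1 to compound 3 (0.24 log units; within the scatter) does not separate it from compound 1.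

Compound 4 `Cc1cc(=O)oc2cc(OCC(=O)NNCc3ccccc3)ccc12` is still unmeasured. It differs from compound 3 at one place: a group of 8 heavy atoms (7 carbon, 1 nitrogen; one six-membered aromatic ring of carbon only) in place of a group of 8 heavy atoms (6 carbon, 1 nitrogen, 1 oxygen; one five-membered aromatic ring with 1 hetero atom), on an amide-type nitrogen. The group that leaves also takes with it the double bond outside aromatic rings.

Among the measured compounds shown here, no measured step removes that double bond, so the data give only indirect guidance. The nearest evidence is the swap of 5-methylfuran-2-yl for a six-membered aromatic ring. Compound 1, at 5540 nM, and compound 2, at 9780 nM, both carry such a ring. A small rise in the number is therefore expected in this assay. The estimated change is a 2.0-fold higher number from compound 3 to compound 4 (0.31 log units; beyond the scatter). The expected value for compound 4 is 6500 nM. The estimated range for compound 4 runs from 2500 nM to 17000 nM.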

Compound 4, half-maximal inhibitory concentration: 1240 nM
Estimate against measurement, compound 4: 5.2-fold (0.72 log units) above; measured number outside the range, below it.
By their numbers in this assay, from the lowest: compound 4; then compounds 3, 1 and 2 (each within the scatter of the next, the first and the last beyond it).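

Among the compounds shown here, the step of a 2.6-fold lower number from compound 3 to compound 4 (0.41 log units; beyond the scatter) in this assay shows that this place on the amide-type nitrogen can lose the double bond outside aromatic rings and still give a lower number, something the earlier compounds could not show, since all of them keep that bond. Benzylamino also brings a hydrogen-bond donor that the leaving group lacks, and it changes the ring at the same time, so this one step bundles several differences together. Nothing measured here explains the drop in the number.

The compounds shown leave open whether the ring or the lost double bond matters more, as no pair differs in the double bond alone. On these data alone, how a fluoro or dimethylamino group on the benzylamino ring, or a longer chain such as phenethylamino, would behave also remains open.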